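Moving a Fluorine Around the Terminal Phenyl Ring

This account rests on a few compounds, and the source may have more. Where it says the series, first, only, none or still open, it means among the compounds named here.

Compound 3 `COc1cc2ncnc(NCc3cccc(NC(=O)Nc4ccccc4F)c3)c2cc1OC` stands second highest of three numbers in a functional assay on MGC-803 cells (Homo sapiens) for antiproliferative activity, read by MTT assay (on this read-out lower numbers stand for stronger inhibition and higher numbers for weaker inhibition), giving 10300 nM. Compound 1 `COc1cc2ncnc(NCc3cccc(NC(=O)Nc4ccccc4)c3)c2cc1OC` gives 10000 nM in this assay, and the step of a 1.0-fold higher number from compound 1 to compound 3 (0.01 log units; within the scatter). Compound 2 `COc1cc2ncnc(NCc3cccc(NC(=O)Nc4ccc(C)cc4)c3)c2cc1OC` gives 34200 nM; the step of a 3.4-fold higher number from compound 1 to compound 2 (0.53 log units; beyond the scatter), while a 3.3-fold lower number from compound 2 to compound 3 (0.52 log units; beyond the scatter). Compound 4 `COc1cc2ncnc(NCc3cccc(NC(=O)Nc4ccc(F)cc4)c3)c2cc1OC` differs from compound 3 by 4-fluorophenyl in place of 2-fluorophenyl on an amide-type nitrogen. Going by the values given here, two measured steps bear on this: placing a methyl on an aromatic carbon, from compound 1 to compound 2, weakened inhibition modestly, whereas adding fluorine, from compound 1 to compound 3, stayed within the scatter. A small weakening, or no change beyond the scatter, is therefore expected. Compound 4 is expected to give 15000 nM in this assay, between 6000 nM and 40000 nM, a step of a 1.5-fold higher number from compound 3 to compound 4 (0.16 log units; within the scatter).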

Compound 4, half-maximal inhibitory concentration: 42100 nM
Estimate against measurement, compound 4: 2.8-fold (0.45 log units) below, outside the stated range (above it).
By their numbers in this assay, from the lowest: compounds 1 and 3 (each within the scatter of the next); then compounds 2 and 4 (each within the scatter of the next).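

The place of the fluorine on the terminal ring matters, not just its presence: with the same atoms joined differently, 4-fluorophenyl in place of 2-fluorophenyl gives a 4.1-fold higher number from compound 3 to compound 4 (0.61 log units; beyond the scatter). Compared with the unsubstituted phenyl, the 4-fluorophenyl group gives a 4.2-fold higher number from compound 1 to compound 4 (0.62 log units; beyond the scatter), and fluoro in place of methyl at that ring carbon stays within the scatter, at a 1.2-fold higher number from compound 2 to compound 4 (0.09 log units; within the scatter). No measurement here explains why these groups behave this way.
As far as these compounds go, it remains open whether 4-chlorophenyl or 4-methoxyphenyl would fall with compound 2 and compound 4. From the compounds shown here alone, it also remains open whether 2-methylphenyl would stay within the scatter of compound 1, as compound 3 does.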